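Aryl swap on the shared core: toward compound 3

This account rests on a few compounds, and the source may have more. Where it says the series, first, only, none or still open, it means among the compounds named here.

Measured so far:
compound 1, `CCN(CC)CCCn1c(=O)c(=Cc2cc(OC)c(OC)c(OC)c2)s/c1=C1\C(=O)Nc2ccc(C)cc21`, 2670 nM
compound 2, `CN(C)CCn1c(=O)c(=Cc2ccc(F)cc2F)s/c1=C1\C(=O)Nc2cc(F)ccc21`, 3200 nM

In a functional assay on NCI-H460 cells (Homo sapiens) for inhibition, read by MTT assay, with a stated time of 72 h (on this read-out higher numbers stand for weaker inhibition and lower numbers for stronger inhibition), compound 2 gives 3200 nM, and compound 1 gives 2670 nM; the two numbers lie within the scatter of each other, so neither stands apart from the other on this read-out.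

Compound 3, `CN(C)CCn1c(=O)c(=Cc2ccc(C=O)c(C=O)c2)s/c1=C1\C(=O)Nc2cc(F)ccc21`, is not yet measured. It differs from compound 2 in one place: 3,4-diformylphenyl in place of 2,4-difluorophenyl on a double-bonded chain carbon bound to an aromatic carbon. Within the data shown here, no measured pair traces this kind of swap, so the size of its effect is not known from the data at hand.

Both measured aryl groups on this core sit in a narrow band of weak inhibition in this assay, so a step of no more than the scatter is expected, with the estimated step from compound 2 to compound 3 being a 1.1-fold higher number from compound 2 to compound 3 (0.04 log units; within the scatter). Compound 3 is expected to give about 3500 nM in this assay, with a range from 1000 nM to 12000 nM.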

Compound 3, half-maximal inhibitory concentration: 2810 nM
For compound 3 the middle estimate is 1.2-fold (0.10 log units) above the measured one; low and high end bracket the measured number.
By their numbers in this assay, from the lowest: compounds 1, 3 and 2 (each within the scatter of the next).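

In this assay, among these compounds, the first one-place comparison gives a 1.1-fold lower number from compound 2 to compound 3 (0.06 log units; within the scatter) for 3,4-diformylphenyl in place of 2,4-difluorophenyl on a double-bonded chain carbon bound to an aromatic carbon. At this position, both fluorines can therefore give way to two formyl groups, with hydrogen-bond acceptors on the group going from 0 to 2, without a step beyond the scatter. No supporting measurement bears on this result.

Still open, from the compounds shown here alone, is whether this flat response extends to groups of another kind, such as a phenyl carrying a carboxylic acid or an amine. A phenyl with a single formyl group would also show whether one formyl group behaves as the pair does.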